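Piperidine for Dimethylamine on the Methoxy Core

The source may report more compounds than this note shows. Statements on the series, on what has been measured and on what is new or still open speak of the compounds shown alone.

compound 1 `CN(C)CCNc1n[n+]([O-])c2ccc(C(C)(C)C)cc2[n+]1[O-]` — 1100 nM
compound 2 `CC(C)(C)c1ccc2c(c1)[n+]([O-])c(NCCN1CCCCC1)n[n+]2[O-]` — 600 nM
compound 3 `COc1ccc2c(c1)[n+]([O-])c(NCCN(C)C)n[n+]2[O-]` — 2900 nM

All three were measured in a functional assay on SiHa cells (Homo sapiens) for cytotoxicity, with a stated time of 4 h; a lower number here means a stronger inhibitor, a higher number a weaker inhibitor. Compound 2 differs from compound 1 by piperidin-1-yl in place of dimethylamino on a saturated chain carbon, two bonds along the chain from a nitrogen on an aromatic ring, and this step reads a 1.8-fold lower number from compound 1 to compound 2 (0.26 log units; within the scatter). Compound 3 differs from compound 1 in its core by methoxy in place of tert-butyl on an aromatic carbon, a step of a 2.6-fold higher number from compound 1 to compound 3 (0.42 log units; beyond the scatter). For the measured compounds named here, compound 4 `COc1ccc2c(c1)[n+]([O-])c(NCCN1CCCCC1)n[n+]2[O-]` has not yet been measured; it differs from compound 3 by piperidin-1-yl in place of dimethylamino on a saturated chain carbon, two bonds along the chain from a nitrogen on an aromatic ring, the same change as the one from compound 1 to compound 2, here made on the core of compound 3. Since compound 3 stands at 2900 nM and the earlier step read a 1.8-fold lower number from compound 1 to compound 2 (0.26 log units; within the scatter), a step of a 1.8-fold lower number from compound 3 to compound 4 (0.26 log units; within the scatter) is expected. Compound 4 is thus estimated at 1600 nM, with the likely range running from 800 nM to 3500 nM.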

Compound 4, half-maximal inhibitory concentration: 3000 nM
For compound 4 the middle estimate is 1.9-fold (0.27 log units) below the measured one, within the range that was stated.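

In this assay, piperidin-1-yl in place of dimethylamino on the methoxy core gives a 1.0-fold higher number from compound 3 to compound 4 (0.01 log units; within the scatter), and the two cores agree on this change: the same change on two cores in this assay, a 1.8-fold lower number (0.26 log units; within the scatter) from compound 1 to compound 2 and a 1.0-fold higher number (0.01 log units; within the scatter) from compound 3 to compound 4, 1.9-fold (0.28 log units) apart, within the scatter of two such steps
Methoxy in place of tert-butyl, read on the piperidin-1-yl side chain, gives a 5.0-fold higher number from compound 2 to compound 4 (0.70 log units; beyond the scatter), and this change also agrees across the two side chains: the same change on two cores in this assay, a 2.6-fold higher number (0.42 log units; beyond the scatter) from compound 1 to compound 3 and a 5.0-fold higher number (0.70 log units; beyond the scatter) from compound 2 to compound 4, 1.9-fold (0.28 log units) apart, within the scatter of two such steps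
Both changes therefore carry over within this set of four compounds, but neither amine step lies beyond the scatter, so no effect of that swap is shown on either core, and four compounds say nothing about other cores.

The compounds shown leave open whether a morpholine or a longer chain would behave the same way. They also leave open whether a core carrying a chlorine atom or a trifluoromethyl group would follow these steps.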